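The compounds below may be only part of what the source reports. "The series", "measured", "known", "first", "only" and "open" are said of these compounds alone.

Compound 1 `Cc1cc(Nc2cc(-c3ccccc3)[nH]n2)n2nc(SCCCc3ccccc3)nc2n1` is one of three close relatives that share a core and differ only in the group attached to a saturated chain carbon bound to a sulfur. In an ADME assay on GES1 cells (Homo sapiens) for inhibition, read by MTT assay, with a stated time of 72 h (on this read-out higher numbers stand for weaker inhibition and lower numbers for stronger inhibition), compound 1 gives 40200 nM, the highest of the two plain numbers shown. Compound 2 `Cc1cc(Nc2cc(-c3ccccc3)[nH]n2)n2nc(SCc3ccc(Cl)cc3)nc2n1` gives 31800 nM in this assay, a change of a 1.3-fold lower number from compound 1 to compound 2 (0.10 log units; within the scatter). Compound 3 `Cc1cc(Nc2cc(-c3ccccc3)[nH]n2)n2nc(SCc3cccc(Br)c3)nc2n1` reaches only a limit of this assay, > 50000 nM, so it carries no number. Compound 3 is one of the values described by the limit of > 50000 nM in this assay, at which 1 of the 3 values shown sits.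

Compound 4 `Cc1cc(Nc2cc(-c3ccccc3)[nH]n2)n2nc(SCc3nc4ccccc4[nH]3)nc2n1` has not been measured. It differs from compound 1 by 1H-benzimidazol-2-yl in place of phenethyl on a saturated chain carbon bound to a sulfur. Both measured steps from compound 1 swap the same phenethyl for an aromatic group at this place, and neither moved the number beyond the scatter: a 1.3-fold lower number from compound 1 to compound 2 (0.10 log units; within the scatter) and an at least 1.2-fold higher number from compound 1 to compound 3 (0.09 log units; that floor lies within the scatter). Compound 4 is therefore expected to sit near compound 1, with a step of a 1.0-fold lower number from compound 1 to compound 4 (0.00 log units; within the scatter). The estimate for compound 4 in this assay is 40000 nM, between 15000 nM and 50000 nM.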

Compound 4, half-maximal inhibitory concentration: 27800 nM
Beside the measured number, compound 4's estimate is 1.4-fold (0.16 log units) above it; the measured number falls inside the stated range.
By their numbers in this assay, from the lowest: compounds 4, 2 and 1 (each within the scatter of the next). At a limit, above all of these: compound 3.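

Swapping phenethyl for 1H-benzimidazol-2-yl adds a second ring with nitrogen, along with a hydrogen-bond donor and acceptor, yet in this assay the reading stays within the scatter, with a 1.4-fold lower number from compound 1 to compound 4 (0.16 log units; within the scatter). The same holds against the chlorinated relative, with a 1.1-fold lower number from compound 2 to compound 4 (0.06 log units; within the scatter), so at this place on a saturated chain carbon bound to a sulfur, these three groups cannot be told apart by this read-out. The comparison with the brominated relative gives only a floor, an at least 1.7-fold lower number from compound 3 to compound 4 (0.25 log units; that floor lies within the scatter), and compound 3 itself stands at a limit of the assay rather than a number: the limit of > 50000 nM in this assay, at which 1 of the 4 values shown sits.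

Every group shown here carries an aromatic ring, so it remains open how an amine or a carboxylic acid at this place would read. Changes elsewhere on the shared core also remain open.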